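Swapping an Ethyl for a Ring-Bearing Carbonyl Group

A few compounds are considered here, and "the series" means these few. Any claim that something is new, unique, unknown or untested is made for them only; others in the source may bear on it.

Of the compounds shown here, three sharing one fused core have been tested in an assay on HEK293 cells for negative allosteric modulation of metabotropic glutamate receptor 5 (Homo sapiens), read by FLIPR, with a stated time of 1 h; on this read-out higher numbers stand for weaker inhibition and lower numbers for stronger inhibition. Compound 1, `O=C1NCCc2nc(C#Cc3cccc(F)c3)sc21`, returns only a limit of the assay, > 10000 nM, not a number. Compound 3, `O=C(C1CC(F)(F)C1)N1CCc2nc(C#Cc3cccc(F)c3)sc2C1`, likewise returns a limit, > 10000 nM. Compound 2, `CCN1CCc2nc(C#Cc3ccccc3)sc2C1`, is the only one to give a measured number, 1200 nM, so it stands alone as the one active point among the three. Compound 1 and compound 3 both sit at the limit (the limit of > 10000 nM in this assay, at which 2 of the 3 values shown sit).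

The next compound, compound 4, `O=C(C1CCCO1)N1CCc2nc(C#Cc3ccccc3)sc2C1`, differs from compound 2 in one place: (oxolan-2-yl)carbonyl in place of ethyl on an amine nitrogen in a ring. Among the compounds with values here, no measured pair differs in just this way, so the expectation rests on the overall picture, in which two of the three values sit at the limit of > 10000 nM in this assay, at which 2 of the 3 values shown sit, and compound 2 is a weak inhibitor to begin with. A step toward weaker inhibition, well beyond the scatter, is expected, with a real chance that only a limit is reported. Compound 4 is expected to come out near 8000 nM, within 2500 nM to 30000 nM. This corresponds to an expected step of a 6.7-fold higher number from compound 2 to compound 4 (0.82 log units; beyond the scatter) toward weaker inhibition.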

Compound 4, half-maximal inhibitory concentration: > 10000 nM
Compound 4: only a limit was reported (the forecaster's own chance of this, stated with the estimate: 40%); at least 1.2-fold (0.09 log units) between middle value and limit.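

Within the data shown here, this is the first direct comparison at the amine nitrogen in the ring: with everything else unchanged, (oxolan-2-yl)carbonyl in place of ethyl gives an at least 8.3-fold higher number from compound 2 to compound 4 (0.92 log units; beyond the scatter) in this assay. The inhibition measurable with ethyl on this nitrogen therefore does not survive this larger group, so the position is sensitive to what it carries. Compound 4 gives only a limit, which places it with most of the compounds shown: the limit of > 10000 nM in this assay, at which 3 of the 4 values shown sit.

From the compounds shown here alone, what remains open is whether the loss follows from the carbonyl or from the oxolane ring, and a simple acetyl group on the same nitrogen would help separate the two. It is also unclear whether a methyl group, a longer chain such as propyl or a benzyl group would keep, improve or lose the inhibition seen with ethyl.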